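Phenyl for pyridyl at the chain carbon of compound 2

The source may report more compounds than this note shows. Statements on the series, on what has been measured and on what is new or still open speak of the compounds shown alone.

Compound 2 `CCc1cc(Nc2nc(N[C@@H](C)c3ccc(F)cn3)nc3cccc(F)c23)n[nH]1` gives 29 nM in an assay on isolated protein for inhibition of G protein-coupled receptor kinase 6 (Homo sapiens), read by scintillation counting, radiometric assay and 33P incorporation, with a stated time of 80 min, in the presence of a further agent that is not named here (a lower number here means a stronger inhibitor, a higher number a weaker inhibitor), and is the higher of the two numbers recorded. Within the data shown here, compound 1 `CCc1cc(Nc2nc(N[C@@H](C)c3ccc(F)cn3)nc3cccc(C)c23)n[nH]1` gives 11 nM in this assay, the step of a 2.6-fold higher number from compound 1 to compound 2 (0.42 log units; beyond the scatter) being the only change within the scatter's reach of compound 2. Compound 3 `CCOc1ccc(Nc2nc(N[C@@H](C)c3ccc(F)cn3)nc3cccc(F)c23)cn1` returns only a limit of the assay in this assay, at > 10000 nM (the limit of > 10000 nM in this assay, at which 1 of the 3 values shown sits). The step of an at least 340-fold higher number from compound 2 to compound 3 (2.53 log units; beyond the scatter) shows that exchange of the pyrazole amine partner can abolish measurable inhibition.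

Compound 4 `CCc1cc(Nc2nc(N[C@@H](C)c3ccc(F)cc3)nc3cccc(F)c23)n[nH]1` differs from compound 2 at a third place: 4-fluorophenyl in place of 5-fluoropyridin-2-yl on a saturated chain carbon bound to a nitrogen on an aromatic ring and a saturated chain carbon. Among the measured compounds shown here, neither measured step touches this chain carbon, so no direct precedent exists; the core substituent step was modest and the pyrazole exchange large. The change here is small in atom count and far from the pyrazole, so a modest loss is expected rather than a collapse. For compound 4 the expected step is a 2.1-fold higher number from compound 2 to compound 4 (0.32 log units; beyond the scatter). Compound 4 is therefore estimated at 60 nM, within 20 nM to 300 nM.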

Compound 4, half-maximal inhibitory concentration: 41 nM
Compound 4: middle estimate off by 1.5-fold (0.17 log units), on the high side, and the stated range covers the measured number.
By their numbers in this assay, from the lowest: compound 1; then compounds 2 and 4 (each within the scatter of the next). At a limit, above all of these: compound 3.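

In this assay, among these compounds, 4-fluorophenyl in place of 5-fluoropyridin-2-yl on the saturated chain carbon gives a 1.4-fold higher number from compound 2 to compound 4 (0.15 log units; within the scatter), the first reading at this position. In this pair, a six-membered aromatic ring of carbon only stands where the ring with one hetero atom stood, and the hydrogen-bond acceptor of that ring goes without a change beyond the scatter. No measurement at hand bears on why the two rings read alike.

Open, going by these compounds, is whether this chain carbon accepts anything other than a fluorinated six-membered aromatic ring, such as a cyclohexyl ring, a morpholine or a carboxylic acid. Also open, on these data alone, is whether the same exchange reads alike on the core of compound 1.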